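Swapping Chloro for Hydroxyethylamino on a Small Core

This account rests on a few compounds, and the source may have more. Where it says the series, first, only, none or still open, it means among the compounds named here.

Compound 3 `Clc1[nH]ccc2ncnc1-2` is the smallest structure among those tested in a functional assay on EL4 cells (Mus musculus) for inhibition, tested at 100 uM; a lower number here means less inhibition, a higher number more inhibition at the concentration tested (going by the name of the read-out). Compound 3 gives < 5%, which is a limit of the assay rather than a measured number. That limit is shared more widely here: the limit of < 5% in this assay, at which 2 of the 3 values shown sit. Compound 1 `OC[C@H]1O[C@@H](n2cnc3c(NCc4ccccc4)nccc32)C[C@@H]1O` gives 8%. Compound 2 `CSc1nccc2c1ncn2C1O[C@H](CO)[C@@H](O)[C@H]1O` gives < 5%, again only a limit. Compound 4 `OCCNc1[nH]ccc2ncnc1-2` has not yet been measured; it differs from compound 3 by (2-hydroxyethyl)amino in place of chloro on an aromatic carbon. Among the measured compounds shown here, with no measured step of this kind available among the three compounds, and all values shown sitting low, the expected step of a number no lower from compound 3 to compound 4 (the limit leaves the size open) is one of no change beyond the scatter. Compound 4 is therefore estimated to give about 5%, within a range from 0% to 15%.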

Compound 4, a percentage reported as inhibition, at one concentration (the size of the read-out at that concentration, not a potency): < 5%
Compound 4 was reported as a limit (the forecaster's own chance of this, stated with the estimate: 60%); the middle value sits exactly at the limit.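

Compound 3 and compound 4 both sit at a limit of the assay, so no step can be read for this swap: the limit of < 5% in this assay, at which 3 of the 4 values shown sit.

The compounds shown leave open whether any single change on the core of compound 3 gives a readable value in this assay.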